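The source may hold more compounds than are shown below. What is called first, only, known or untested is meant among the compounds shown, and "the series" means these compounds.

Measured so far in a functional assay on HL-60 cells (Homo sapiens) for cytotoxicity, read by MTT assay, with a stated time of 4 days; a lower number here means a stronger inhibitor, a higher number a weaker inhibitor:
compound 1 `C=C1C[C@]23C[C@@]1(O)CC[C@H]2c1cc(Br)c(O)c(C)c1[C@@H]3Cn1cc(-c2ccc(C)cc2)nn1` — > 20000 nM.
compound 2 `C=C1C[C@]23C[C@@]1(O)CC[C@H]2c1cc(Br)c(O)c(C)c1[C@@H]3Cn1cc(-c2ccc(Cl)cc2)nn1` — 5590 nM.

The value of compound 1 in this assay is a limit, not a number. Going by the values given here, compound 2 gives 5590 nM in this assay, the only number. Among the compounds with values here, the one other value, that of compound 1, is a limit (the limit of > 20000 nM in this assay, at which 1 of the 2 values shown sits). Within the data shown here, the single measured step is an at least 3.5-fold lower number from compound 1 to compound 2 (0.55 log units; beyond the scatter), the change being chloro in place of methyl on an aromatic carbon.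

Compound 3 `C=C1C[C@]23C[C@@]1(O)CC[C@H]2c1cc(Br)c(O)c(C)c1[C@@H]3Cn1cc(-c2ccc(OC)cc2)nn1` differs from compound 2 by methoxy in place of chloro on an aromatic carbon. Among the measured compounds shown here, the one measured step changes the group on that same aromatic carbon, so it is the only guide, and it showed a modest movement. Methoxy has not been measured in this series, so the direction is uncertain; the number for compound 3 is expected to lie closer to the limit seen for compound 1, with an estimated step of a 2.1-fold higher number from compound 2 to compound 3 (0.33 log units; beyond the scatter). Compound 3 is estimated at 12000 nM, with a range from 4000 nM to 30000 nM.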

Compound 3, half-maximal inhibitory concentration: > 20000 nM
Compound 3 ended at the assay's limit (the forecaster's own chance of this, stated with the estimate: 40%); middle value at least 1.6-fold (0.22 log units) away from the limit.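

In this assay, methoxy in place of chloro on this aromatic carbon gives an at least 3.5-fold higher number from compound 2 to compound 3 (0.55 log units; beyond the scatter), so the number seen with compound 2 does not carry over to the oxygen-linked group. Of the three groups shown at this position, only chloro gives a number, while methyl in compound 1 and methoxy in compound 3 both end at the assay's limit: the limit of > 20000 nM in this assay, at which 2 of the 3 values shown sit. Both of those values are limits, so the step between compound 1 and compound 3 cannot be read, and methyl and methoxy cannot be ordered.

On these data alone, whether fluoro, bromo, trifluoromethyl or a nitrile on this carbon would match or pass compound 2 remains open. Also open, as far as these compounds go, is how an amine or a carboxylic acid at the same place would read, and whether changes to the shared core would shift these numbers.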